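A few compounds are considered here, and "the series" means these few. Any claim that something is new, unique, unknown or untested is made for them only; others in the source may bear on it.

Notes on the series. Compound 1 `CCN(Cc1c(C(F)(F)F)nc2n(-c3c(C)cc(C)cc3C)c(Cl)cn12)CC1CC1` gives 9 nM in an assay on cells for displacement of a labelled ligand from corticotropin-releasing factor receptor 1 (Homo sapiens), with a stated time of 100 min; a lower number here means a stronger inhibitor, a higher number a weaker inhibitor. Compound 2 `C=CCN(CC=C)Cc1c(C(F)(F)F)nc2n(-c3c(C)cc(C)cc3C)c(Cl)cn12` gives 13 nM in this assay, with a 1.4-fold higher number from compound 1 to compound 2 (0.16 log units; within the scatter). Compound 3 `CCN(Cc1ccccc1)Cc1c(C(F)(F)F)nc2n(-c3c(C)cc(C)cc3C)c(Cl)cn12` gives 350 nM, the highest number of the three; the steps of a 39-fold higher number from compound 1 to compound 3 (1.59 log units; beyond the scatter) and a 27-fold higher number from compound 2 to compound 3 (1.43 log units; beyond the scatter) both show the benzyl-bearing amine of compound 3 as the weaker inhibitor, beyond the scatter. Compound 4 `Cc1cc(C)c(-n2c(Cl)cn3c(CN4CCCC(C)C4)c(C(F)(F)F)nc23)c(C)c1` differs from compound 3 by 3-methylpiperidin-1-yl in place of benzyl(ethyl)amino on a saturated chain carbon bound to an aromatic carbon. This removes the six-membered aromatic ring of carbon only and returns to a non-aromatic substituent on the nitrogen, the kind seen in compound 1 and compound 2, where the steps of a 39-fold higher number from compound 1 to compound 3 (1.59 log units; beyond the scatter) and a 27-fold higher number from compound 2 to compound 3 (1.43 log units; beyond the scatter) were large; a large step to a lower number is therefore expected, a 23-fold lower number from compound 3 to compound 4 (1.37 log units; beyond the scatter). Compound 4 is estimated at 15 nM, with a range from 5 nM to 50 nM.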

Compound 4, inhibition constant: 5800 nM
Compound 4: middle estimate off by 390-fold (2.59 log units), on the low side; the measured number lies above the stated range.
By their numbers in this assay, from the lowest: compounds 1 and 2 (each within the scatter of the next); then compound 3; then compound 4.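

In this assay, 3-methylpiperidin-1-yl on the saturated chain carbon bound to an aromatic carbon does not return the series to the level of the open-chain amines (a 17-fold higher number from compound 3 to compound 4 (1.22 log units; beyond the scatter); a 450-fold higher number from compound 2 to compound 4 (2.65 log units; beyond the scatter); a 640-fold higher number from compound 1 to compound 4 (2.81 log units; beyond the scatter)). Removing the aromatic ring is therefore not enough at this position, and compound 4, with the ring-closed amine, is the weakest of the four. Nothing on hand accounts for this loss.

Going by these compounds, whether the piperidine ring itself or its methyl carries the loss stays open. An unsubstituted piperidine or a morpholine would help to separate the two.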